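The source may report more compounds than this note shows. Statements on the series, on what has been measured and on what is new or still open speak of the compounds shown alone.

In a functional assay on HCT-15 cells (Homo sapiens) for cytotoxicity, read by CCK-8 assay and cell counting, with a stated time of 2 days (a higher number here means a weaker inhibitor, a lower number a stronger inhibitor), compound 1 `Oc1ccc(-c2cc(-c3ccc(Cl)cc3)nc(-c3cccnc3)c2)cc1` gives 20700 nM and compound 3 `Oc1ccc(-c2cc(-c3cccnc3)nc(-c3cccc(Cl)c3)c2)cc1` gives 21300 nM. Among the measured compounds shown here, the one change between them, (3-chlorophenyl in place of 4-chlorophenyl on an aromatic carbon), made a 1.0-fold higher number from compound 1 to compound 3 (0.01 log units; within the scatter). Compound 2 `Oc1cccc(-c2cc(-c3ccc(Cl)cc3)nc(-c3ccsc3)c2)c1` gives 8850 nM in this assay, the lowest of the three numbers; the difference between the core of compound 2 and that of compound 1 is not broken down here. Compound 4 `Oc1cccc(-c2cc(-c3ccsc3)nc(-c3cccc(Cl)c3)c2)c1` has not yet been measured in this assay. It differs from compound 2 by 3-chlorophenyl in place of 4-chlorophenyl on an aromatic carbon, the same kind of change as from compound 1 to compound 3, though here the place is meta to a 3-hydroxyphenyl group and to a thiophen-3-yl group rather than to a 4-hydroxyphenyl group and a pyridin-3-yl group. Because a 1.0-fold higher number from compound 1 to compound 3 (0.01 log units; within the scatter) stayed within the scatter, the expected step is a 1.0-fold higher number from compound 2 to compound 4 (0.01 log units; within the scatter). Compound 4 is therefore estimated at 9000 nM in this assay, within 4000 nM to 20000 nM.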

Compound 4, half-maximal inhibitory concentration: 2510 nM
Beside the measured number, compound 4's estimate is 3.6-fold (0.55 log units) above it; measured number outside the range, below it.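

In this assay the swap of 3-chlorophenyl for 4-chlorophenyl gave a 3.5-fold lower number from compound 2 to compound 4 (0.55 log units; beyond the scatter), so the change did not carry over at the same size from one core to the other: the same change on two cores in this assay, a 1.0-fold higher number (0.01 log units; within the scatter) from compound 1 to compound 3 and a 3.5-fold lower number (0.55 log units; beyond the scatter) from compound 2 to compound 4, 3.6-fold (0.56 log units) apart, beyond the scatter of two such steps. Among the compounds shown here, the pairs show that the step depends on its core, but with only one pair on each core they do not establish a general rule for the series. The cores differ in both 3-hydroxyphenyl versus 4-hydroxyphenyl and thiophen-3-yl versus pyridin-3-yl, and these pairs do not show which of the two matters.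

The compounds shown leave open how the step behaves when only one of those two groups is exchanged. They also leave open whether it would persist with an amine in place of the hydroxyl group or with fluorine in place of chlorine.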